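Ketone aryl variation in the series: cytotoxicity notes

This account rests on a few compounds, and the source may have more. Where it says the series, first, only, none or still open, it means among the compounds named here.

Compound 1 `O=C(c1ccc(F)c(F)c1)C1CCN(Cc2coc(-c3ccc(F)cc3)n2)CC1`: > 150 ug/mL in an ADME assay on HEK293 cells (Homo sapiens) for cytotoxicity, read by MTT assay, with a stated time of 36 h (a lower number here means a stronger inhibitor, a higher number a weaker inhibitor), a limit of the assay.
Compound 2 `O=C(c1ccccc1)C1CCN(Cc2coc(-c3ccc(F)cc3)n2)CC1`: > 150 ug/mL in this assay, a limit of the assay.

Compound 2 stands at the assay limit in this assay, as the limit of > 150 ug/mL in this assay, at which 2 of the 2 values shown sit, shows. The step that the two limits leave unreadable from compound 1 to compound 2 therefore gives no readable size. Compound 3 `Cc1ccc(C(=O)C2CCN(Cc3coc(-c4ccc(F)cc4)n3)CC2)cc1C` carries 3,4-dimethylphenyl in place of phenyl on a carbonyl carbon. Within the data shown here, no measured step bears readably on this change, since both measured values are limits. No shift beyond the scatter is expected, and compound 3 is expected to remain at the limit, estimated at 200 ug/mL with a range of 100 ug/mL to 500 ug/mL, a step that the limit leaves unreadable from compound 2 to compound 3.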

Compound 3, half-maximal inhibitory concentration: > 150 ug/mL
Compound 3 gave a limit, no number; the forecaster's own chance of this, stated with the estimate: 85%; the middle value lies beyond the limit too.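

No step among compound 1, compound 2 and compound 3 can be read, since all three values are limits of the assay: the limit of > 150 ug/mL in this assay, at which 3 of the 3 values shown sit.

The compounds shown leave open whether phenyl, 3,4-difluorophenyl and 3,4-dimethylphenyl differ at all in this assay.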